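This account rests on a few compounds, and the source may have more. Where it says the series, first, only, none or still open, it means among the compounds named here.

Going by the values given here, compound 2 `COc1cc(O)c(C(=O)c2cccc(Cl)c2)c(OC)c1` stands lowest of the two numbers so far in a functional assay on THP-1 cells (Homo sapiens) for inhibition, read by ELISA, with stated times of 30 min and 24 h, tested at 10 uM (a higher number here means a stronger effect of the compound at the concentration tested, a lower number a weaker effect), where compound 2 gives 78%; compound 1 `COc1cc(OC)c(C(=O)c2cccc(Cl)c2)c(O)c1CN1CCCCC1` gives 83%, and the step of a number 5 percentage points lower from compound 1 to compound 2 (within the scatter) lies within the scatter. Compound 3 `COc1cc(OC)c(C(=O)c2cccc(Cl)c2)c(O)c1CN1CCCC1` carries (pyrrolidin-1-yl)methyl in place of hydrogen on an aromatic carbon. Among the compounds with values here, the only step that bears on it, hydrogen in place of (piperidin-1-yl)methyl, was small, so no change beyond the scatter is expected in this assay. Compound 3 is therefore expected near 82%, between 70% and 92%. That amounts to an expected step of a number 4 percentage points higher from compound 2 to compound 3 (within the scatter).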

Compound 3, a percentage reported as activity, at one concentration (the size of the read-out at that concentration, not a potency): 81%
Compound 3: the middle estimate sits 1 percentage points above what was measured; the measured number falls inside the stated range.
By their numbers in this assay, from the lowest: compounds 2, 3 and 1 (each within the scatter of the next).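

In this assay, placing (pyrrolidin-1-yl)methyl on this aromatic carbon gives a number 3 percentage points higher from compound 2 to compound 3 (within the scatter) and so, like (piperidin-1-yl)methyl, does not separate from the hydrogen of compound 2. Exchanging the ring itself gives a number 2 percentage points lower from compound 1 to compound 3 (within the scatter), so the five-membered ring and the six-membered ring cannot be told apart here. Nothing at hand accounts for these results. The compounds shown leave open whether a morpholine ring, a dimethylamino group or a longer chain on this carbon would move the read-out beyond the scatter.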